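The source may report more compounds than this note shows. Statements on the series, on what has been measured and on what is new or still open speak of the compounds shown alone.

Measured in a functional assay on KYSE-70 cells for antiproliferative activity against KYSE-70 cell line (Homo sapiens), read by MTT assay, with a stated time of 72 h; on this read-out lower numbers stand for stronger inhibition and higher numbers for weaker inhibition:
- compound 1 `O=C(Nc1cccc(F)c1)c1cc(=O)[nH]c2cc(Br)ccc12`: 8900 nM
- compound 2 `O=C(Nc1cccc(F)c1)c1cc(=O)[nH]c2cc(-c3cccc(F)c3)ccc12`: 12000 nM

Among the compounds with values here, only these two compounds have numbers so far, and they lie close together: the step is a 1.3-fold higher number from compound 1 to compound 2 (0.13 log units; within the scatter). Compound 1 therefore does not stand apart from compound 2, and both sit in the same range in this assay.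

The next compound, compound 3 `O=C(Nc1cccc(F)c1)c1cc(=O)n(Cc2ccccc2)c2cc(Br)ccc12`, keeps the bromo of compound 1 and changes another part of the molecule: benzyl in place of hydrogen on an aromatic nitrogen. In words, this is benzyl in place of hydrogen on an aromatic nitrogen. Within the data shown here, no measured compound carries a group on that nitrogen, so no measured step tests this change directly. Among the measured compounds shown here, the one measured step bears on it only loosely. It exchanged bromo for a 3-fluorophenyl on an aromatic carbon, and that larger group left the number within the scatter (a 1.3-fold higher number from compound 1 to compound 2 (0.13 log units; within the scatter)). On that thin evidence, no step beyond the scatter is expected, and neither direction is favoured. The estimated step is a 1.0-fold higher number from compound 1 to compound 3 (0.00 log units; within the scatter). For compound 3 the estimated value is 9000 nM, with an expected range of 3000 nM to 25000 nM.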

Compound 3, half-maximal inhibitory concentration: > 20000 nM
Compound 3 gave a limit, no number; the forecaster's own chance of this, stated with the estimate: 10%; at least 2.2-fold (0.34 log units) between middle value and limit.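

In this assay compound 3 gives > 20000 nM, which is a limit of the assay and not a number. Benzyl in place of hydrogen on the aromatic nitrogen gives an at least 2.2-fold higher number from compound 1 to compound 3 (0.35 log units; beyond the scatter), so among the compounds shown, this nitrogen is the first place where a change moves the read-out beyond the scatter, and it moves towards weaker inhibition, whereas the exchange on the aromatic carbon gave a 1.3-fold higher number from compound 1 to compound 2 (0.13 log units; within the scatter). The full size of the step stays unknown because the reading ends at a limit: the limit of > 20000 nM in this assay, at which 1 of the 3 values shown sits.

The compounds shown leave open whether only benzyl has this effect or whether any group on that nitrogen would, for example a simple methyl, a longer chain or a chain ending in an amine or a carboxylic acid. They also leave open whether the same benzyl would give a similar step on the nitrogen of compound 2, which carries 3-fluorophenyl in place of the bromo.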